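Two Amides at the Cytotoxicity Limit, and an Oxetane to Test

This account rests on a few compounds, and the source may have more. Where it says the series, first, only, none or still open, it means among the compounds named here.

Measured in an ADME assay on H9c2 cells (Rattus norvegicus) for cytotoxicity; on this read-out higher numbers stand for weaker inhibition and lower numbers for stronger inhibition:
Compound 1 `O=C(Nc1nc2cc(Cl)ccc2s1)C1CC1`: > 50000 nM
Compound 2 `CCCC(=O)Nc1nc2ccc(Cl)cc2s1`: > 50000 nM

In this assay compound 2 stands at > 50000 nM, which is a limit and not a number. Neither measured compound gives an exact value, and the evidence so far is the limit of > 50000 nM in this assay, at which 2 of the 2 values shown sit. Compound 3 `O=C(Nc1nc2ccc(Cl)cc2s1)C1COC1` differs from compound 2 in one place, with oxetan-3-yl in place of propyl on a carbonyl carbon. The expected change, a number no higher from compound 2 to compound 3 (the limit leaves the size open), is estimated to stay within the scatter, with no clear direction. For compound 3 the expected value is 50000 nM, with an estimated range from 25000 nM to 100000 nM.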

Compound 3, half-maximal inhibitory concentration: > 50000 nM
Compound 3: only a limit was reported; the forecaster's own chance of this, stated with the estimate: 85%; the middle value lies on the limit itself.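

Compound 3 gives > 50000 nM in this assay, which is a limit and not a number. Within the data shown here, compound 2 also stands at a limit, so no step to compound 3 can be read. The compounds shown leave open what exact value compound 1, compound 2 or compound 3 would give in this assay.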